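This account rests on a few compounds, and the source may have more. Where it says the series, first, only, none or still open, it means among the compounds named here.

Measured compounds:
- Compound 1 `CCOCCOC(=O)C(=O)Nc1nc(-c2cc(OC)no2)cs1`: 3 mg/kg
- Compound 2 `CCOCCOC(=O)C(=O)Nc1nc(-c2cc(C(=O)OCC)no2)cs1`: 0.08 mg/kg
- Compound 3 `CCOCCOC(=O)C(=O)Nc1nc(-c2cc(CO)on2)cs1`: 1.8 mg/kg

In a functional assay on the whole organism with Rattus norvegicus as the target (on this read-out lower numbers stand for an effect already at smaller amounts and higher numbers for an effect only at larger amounts of compound), compound 1 gives 3 mg/kg. That places it level with compound 3 once the usual scatter is allowed for, and clearly higher than compound 2, so more of compound 1 is needed for the same effect.

The next compound, compound 4 `COc1cc(-c2csc(NC(=O)C(=O)O)n2)on1`, has not yet been measured. It differs from compound 1 at one place: hydrogen in place of 2-ethoxyethyl on an oxygen next to a carbonyl group. In words, hydrogen stands in place of 2-ethoxyethyl on an oxygen next to a carbonyl group, while the rest of compound 1 stays as it is.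

Two measured steps start from compound 1. One is large, a 38-fold lower number from compound 1 to compound 2 (1.57 log units; beyond the scatter), and the other stays within the scatter, a 1.7-fold lower number from compound 1 to compound 3 (0.22 log units; within the scatter). Both change the other end of the molecule, and all three measured compounds carry the same 2-ethoxyethyl. Going by the values given here, the data therefore hold no step at the place that changes here, and neither step can be carried over to it. With no evidence for a direction, no shift beyond the scatter is expected, though this is a weak expectation. The expected step is no change at the digits printed from compound 1 to compound 4 (within the scatter). For compound 4 the estimated value is 3 mg/kg, with an expected range of 0.5 mg/kg to 15 mg/kg.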

Compound 4, dose for half-maximal effect: 1.2 mg/kg
Beside the measured number, compound 4's estimate is 2.5-fold (0.40 log units) above it; low and high end bracket the measured number.
By their numbers in this assay, from the lowest: compound 2; then compounds 4, 3 and 1 (each within the scatter of the next, the first and the last beyond it).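

In this assay, going by these compounds alone, the step of a 2.5-fold lower number from compound 1 to compound 4 (0.40 log units; beyond the scatter) is the first reading at this position, and it shows that the 2-ethoxyethyl on the oxygen next to the carbonyl group can be replaced by a bare hydrogen without any need for a larger dose. The whole chain can therefore go and the effect in the animal remains, with a modest shift towards smaller amounts; this change matters far less than the one at the other end of the molecule, where the step is a 38-fold lower number from compound 1 to compound 2 (1.57 log units; beyond the scatter) and the position of the new change stays untouched. Nothing in the available data explains why the number moves in this direction.

Going by these compounds, with only hydrogen and 2-ethoxyethyl seen on this oxygen, it stays open how a small methyl, an ethyl or a longer chain would behave there, and whether an amine in place of that oxygen would keep the effect. On these data alone, it also stays open whether the ethoxycarbonyl that lowers the number so strongly in compound 2 would do the same when hydrogen stands on this oxygen.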